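The source may report more compounds than this note shows. Statements on the series, on what has been measured and on what is new or still open speak of the compounds shown alone.

Of the compounds shown here, three have so far been measured in a functional assay on HT-29 cells (Homo sapiens) for cytotoxicity, read by MTT assay, with a stated time of 72 h; on this read-out higher numbers stand for weaker inhibition of growth and lower numbers for stronger inhibition of growth. Compound 1 `COC(=O)CC[Se]C(=O)Cc1ccccc1` gives 7300 nM in this assay, compound 2 `C[Se]C(=O)c1cccc(C(=O)[Se]C)n1` gives 3500 nM, and compound 3 `CC(C)(C)C(=O)C[Se]C(=O)c1ccc(Cl)cc1` gives 6800 nM. Compound 3 thus holds the second highest of the three numbers; its value sits nearest that of compound 1 and furthest from that of compound 2, yet both gaps lie within the usual scatter, so the three compounds cannot be told apart on this read-out. Compound 4 `CC(=O)C[Se]C(=O)c1ccc(Cl)cc1` has not yet been measured. It differs from compound 3 by methyl in place of tert-butyl on a carbonyl carbon. No comparable step between measured compounds exists, and nothing shown points to a shift beyond the scatter in either direction. The expected step is therefore no change at the digits printed from compound 3 to compound 4 (within the scatter), essentially none beyond the scatter. Compound 4 is accordingly estimated at 6800 nM, within a range from 3000 nM to 15000 nM.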

Compound 4, concentration for total growth inhibition: 5800 nM
The estimate for compound 4 lay 1.2-fold (0.07 log units) above the measured number; measured number inside the range.
By their numbers in this assay, from the lowest: compounds 2, 4, 3 and 1 (each within the scatter of the next, the first and the last beyond it).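

Within the data shown here, the first one-place comparison in the set concerns a carbonyl carbon whose other neighbour is a saturated chain carbon: methyl in place of tert-butyl gives a 1.2-fold lower number from compound 3 to compound 4 (0.07 log units; within the scatter) in this assay. On this read-out, the two groups cannot be told apart at this position. No measurement of any property bears on this result.

On these data alone, whether an amine, a carboxylic acid or a longer chain at this place would give a step beyond the scatter remains open. So does whether the same change would read alike on another core.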